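From pent-1-yn-1-yl to ethynyl on compound 1

This account rests on a few compounds, and the source may have more. Where it says the series, first, only, none or still open, it means among the compounds named here.

Of the compounds shown here, two have numbers so far in a functional assay on HeLa cells (Homo sapiens) for cytotoxicity, with a stated time of 72 h; a higher number here means a weaker inhibitor, a lower number a stronger inhibitor. Compound 1 `CCCC#Cc1cn([C@@H]2O[C@H](CO)[C@@H](O)[C@H](O)[C@H]2O)c(=O)nc1N` gives 191000 nM, the higher of the two numbers. Compound 2 `O=c1nc(O)c(C#Cc2ccccc2)cn1[C@@H]1O[C@H](CO)[C@@H](O)[C@H](O)[C@H]1O` gives 5400 nM, and the gap between the two lies beyond the scatter. Compound 1 therefore stands at the weak end of this small set.

The next compound is compound 3 `C#Cc1cn([C@@H]2O[C@H](CO)[C@@H](O)[C@H](O)[C@H]2O)c(=O)nc1N`, which has hydrogen in place of propyl on a triple-bonded carbon of compound 1 (hydrogen in place of propyl on a triple-bonded carbon). The same difference, cut one bond further out, reads pent-1-yn-1-yl to ethynyl.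

Among the measured compounds shown here, no two measured compounds differ in one place only, so no measured step speaks directly for this change. Compound 2 at 5400 nM differs from compound 1 in more than one place and offers no direct guide. In this assay the expectation is therefore no step beyond the scatter, in either direction. The estimated move is a 1.1-fold lower number from compound 1 to compound 3 (0.05 log units; within the scatter). For compound 3 the expected value is 170000 nM, with an estimated range of 50000 nM to 500000 nM.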

Compound 3, half-maximal inhibitory concentration: >= 250000 nM
Compound 3 gave a limit, no number; the forecaster's own chance of this, stated with the estimate: 30%; at least 1.4-fold (0.16 log units) between middle value and limit.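

In this assay compound 3 gives >= 250000 nM, which is a limit of the assay and not a number. Hydrogen in place of propyl on a triple-bonded carbon gives an at least 1.3-fold higher number from compound 1 to compound 3 (0.11 log units; that floor lies within the scatter), the first direct reading of this position: cutting pent-1-yn-1-yl back to ethynyl brings no stronger number, although the floor of the step does not by itself separate the two compounds beyond the scatter. The true size of the step cannot be read because the result for compound 3 rests on a limit: the limit of >= 250000 nM in this assay, at which 1 of the 3 values shown sits.

As far as these compounds go, whether a longer chain, such as hexyl, or a chain ending in an amine or a carboxylic acid on the same triple-bonded carbon would give a lower number than propyl remains open, so the propyl result cannot yet be placed on any trend with chain length. Compound 2 differs from compound 1 in more than one place, so it cannot settle what the group on the triple-bonded carbon contributes on its own.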